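Thiazolyl isomers and a pyrazolyl swap on the shared core

The compounds below may be only part of what the source reports. "The series", "measured", "known", "first", "only" and "open" are said of these compounds alone.

In a functional assay on MCF7 cells (Homo sapiens) for antiproliferative activity, read by CellTiter-Glo, with a stated time of 5 days (on this read-out lower numbers stand for stronger inhibition and higher numbers for weaker inhibition), three thiazolyl groups have been compared on the shared core. Compound 1 `CC/C(=C(/c1ccc(/C=C/C(=O)O)cc1)c1ccc(-c2cncs2)cc1)c1ccccc1` gives 31 nM, compound 2 `CC/C(=C(/c1ccc(/C=C/C(=O)O)cc1)c1ccc(-c2nccs2)cc1)c1ccccc1` gives 290 nM, and compound 3 `CC/C(=C(/c1ccc(/C=C/C(=O)O)cc1)c1ccc(-c2cnsc2)cc1)c1ccccc1` gives 120 nM. Compound 3 therefore holds the second highest of the three numbers, lying between the other two and separated from each beyond the scatter. Its nearest and furthest neighbours are defined by two modest steps: a 2.4-fold lower number from compound 2 to compound 3 (0.38 log units; beyond the scatter) and a 3.9-fold higher number from compound 1 to compound 3 (0.59 log units; beyond the scatter).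

Compound 4 `CC/C(=C(/c1ccc(/C=C/C(=O)O)cc1)c1ccc(-c2cn[nH]c2)cc1)c1ccccc1` carries 1H-pyrazol-4-yl in place of the 1,2-thiazol-4-yl of compound 3, on an aromatic carbon: 1H-pyrazol-4-yl in place of 1,2-thiazol-4-yl on an aromatic carbon. Within the data shown here, no measured compound here has a ring without sulfur, so no measured step covers this exchange directly. The nearest guide is the thiazolyl set, where moving between ring isomers alone gives a 9.4-fold higher number from compound 1 to compound 2 (0.97 log units; beyond the scatter). That spread leaves either direction open and calls for a wide range. No step beyond the scatter is expected, and the expected result is a 1.2-fold lower number from compound 3 to compound 4 (0.08 log units; within the scatter). Compound 4 is estimated at 100 nM, with an expected range of 30 nM to 350 nM.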

Compound 4, half-maximal inhibitory concentration: 40 nM
Beside the measured number, compound 4's estimate is 2.5-fold (0.40 log units) above it; the range from low to high includes it.
By their numbers in this assay, from the lowest: compounds 1 and 4 (each within the scatter of the next); then compound 3; then compound 2.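

In this assay, the change to 1H-pyrazol-4-yl shows that this position, on an aromatic carbon para to a large group, does not depend on a sulfur-bearing ring, with a 3.0-fold lower number from compound 3 to compound 4 (0.48 log units; beyond the scatter) and a larger gain in a 7.3-fold lower number from compound 2 to compound 4 (0.86 log units; beyond the scatter). The best thiazolyl isomer is matched rather than passed, since a 1.3-fold higher number from compound 1 to compound 4 (0.11 log units; within the scatter) leaves no order between those two compounds, so a ring with 1 hydrogen-bond donor and a ring with 0 hydrogen-bond donors reach the same level here. No supporting measurement accounts for the gain over the 1,2-thiazol-4-yl ring or for the parity with the 1,3-thiazol-5-yl ring.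

Still open, as far as these compounds go, is whether the hydrogen on the pyrazole nitrogen matters to this result, which a 1-methyl-1H-pyrazol-4-yl group would test directly. The compounds shown also leave open whether a five-membered ring is needed at all, a question for a six-membered pyridin-4-yl group or a plain phenyl group at the same place on the shared core.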